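A few compounds are considered here, and "the series" means these few. Any claim that something is new, unique, unknown or untested is made for them only; others in the source may bear on it.

In a functional assay on PC-9 cells (Homo sapiens) for inhibition, read by MTT assay, with a stated time of 72 h (on this read-out lower numbers stand for stronger inhibition and higher numbers for weaker inhibition), the three measured compounds stand as follows:

Compound 1, `Cc1cc(Nc2cc(-c3ccccc3)[nH]n2)n2nc(SCCCc3ccccc3)nc2n1`: 5030 nM
Compound 2, `Cc1cc(Nc2cc(-c3ccccc3)[nH]n2)n2nc(SCc3cccc4ccccc34)nc2n1`: 3950 nM
Compound 3, `Cc1cc(Nc2cc(-c3ccccc3)[nH]n2)n2nc(SCC3CC3)nc2n1`: > 50000 nM, which is a limit of the assay and not a number.

Among the compounds with values here, compound 3 is thus the one compound that reaches (the limit of > 50000 nM in this assay, at which 1 of the 3 values shown sits). It stands apart from compound 1 and compound 2, whose values lie within the scatter of each other, as shown by a 1.3-fold lower number from compound 1 to compound 2 (0.10 log units; within the scatter). Compound 4, `Cc1cc(Nc2cc(-c3ccccc3)[nH]n2)n2nc(SCC(=O)c3ccccc3)nc2n1`, is still to be measured. It differs from compound 3 in one place: benzoyl in place of cyclopropyl on a saturated chain carbon bound to a sulfur. Within the data shown here, two measured steps bear on this change, each running the opposite way, from a group carrying an aromatic ring to cyclopropyl: an at least 9.9-fold higher number from compound 1 to compound 3 (0.99 log units; beyond the scatter) and an at least 12-fold higher number from compound 2 to compound 3 (1.10 log units; beyond the scatter). Benzoyl again brings an aromatic ring onto that chain carbon, so a step back toward the numbers of compound 1 and compound 2 is expected, though the carbonyl is new to the series and the return may be partial. Compound 4 is therefore estimated at 8000 nM, between 2500 nM and 30000 nM, meaning an at least 6.2-fold lower number from compound 3 to compound 4 (0.79 log units; beyond the scatter) is expected.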

Compound 4, half-maximal inhibitory concentration: 4450 nM
Estimate against measurement, compound 4: 1.8-fold (0.25 log units) above, within the range that was stated.
By their numbers in this assay, from the lowest: compounds 2, 4 and 1 (each within the scatter of the next). At a limit, above all of these: compound 3.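

In this assay, benzoyl on a saturated chain carbon bound to a sulfur gives an at least 11-fold lower number from compound 3 to compound 4 (1.05 log units; beyond the scatter), so a group with a carbonyl, new to the series, also restores a number far from that of cyclopropyl. It joins the two earlier groups that carry an aromatic ring, with a 1.1-fold higher number from compound 2 to compound 4 (0.05 log units; within the scatter) and a 1.1-fold lower number from compound 1 to compound 4 (0.05 log units; within the scatter), so among compounds 1, 2 and 4 the change of group and the added hydrogen-bond acceptor bring no separation, and only compound 3 goes against this pattern. The first step is only a bound, since compound 3 stands at a limit and not at a number: the limit of > 50000 nM in this assay, at which 1 of the 4 values shown sits.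

The compounds shown leave open whether a group without an aromatic ring, such as a longer alkyl chain, an amine or a carboxylic acid, could also reach these numbers. They also leave open whether fluorine or a methoxy group on the ring of benzoyl would shift the number.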